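Ethoxy for methylamino on the two-nitrogen ring carbon

The compounds below may be only part of what the source reports. "The series", "measured", "known", "first", "only" and "open" are said of these compounds alone.

The series shares one core, varied at the aromatic carbon between two ring nitrogen atoms. In a functional assay (spleen, spleen) for activation, with Mus musculus as the target (a higher number here means that more compound is needed for the effect, a lower number that less compound is needed), compound 1 `CSc1nc(N)c2nc(O)n(Cc3ccccc3)c2n1` gives 0.1 uM, compound 2 `Cc1ccc(Cn2c(O)nc3c(N)ncnc32)cc1` gives 10 uM, and compound 3 `CNc1nc(N)c2nc(O)n(Cc3ccccc3)c2n1` gives 1 uM. Compound 3 thus holds the second highest of the three numbers, set apart from both other compounds beyond the scatter. Among the compounds with values here, the one measured step at this position, a 10-fold higher number from compound 1 to compound 3 (1.00 log units; beyond the scatter), bears on the change. Compound 4 `CCOc1nc(N)c2nc(O)n(Cc3ccccc3)c2n1` carries ethoxy in place of methylamino on an aromatic carbon. As this again exchanges the group on that carbon, undoing the kind of change that raised the number from compound 1, a lower number is expected for compound 4, of similar size. Compound 4 is therefore estimated at 0.1 uM, within 0.02 uM to 0.5 uM, an expected step of a 10-fold lower number from compound 3 to compound 4 (1.00 log units; beyond the scatter).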

Compound 4, minimum effective concentration: 0.1 uM
Beside the measured number, compound 4's estimate shows no gap at the digits printed, within the range that was stated.
By their numbers in this assay, from the lowest: compounds 1 and 4 (each within the scatter of the next); then compound 3; then compound 2.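

In this assay, ethoxy on the aromatic carbon between two ring nitrogen atoms gives a 10-fold lower number from compound 3 to compound 4 (1.00 log units; beyond the scatter), so the higher number of compound 3 is not shared by every replacement at this carbon. Ethoxy and methylsulfanyl read alike, with no change at the digits printed from compound 1 to compound 4 (within the scatter), leaving methylamino as the one group of the three that stands apart. No measurement at hand explains that gap. From the compounds shown here alone, whether a longer chain such as propoxy, or dimethylamino, would read with ethoxy or with methylamino stays open.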